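Spiro-fused quinoxaline series: a bromophenyl shift on the triazole

The compounds below may be only part of what the source reports. "The series", "measured", "known", "first", "only" and "open" are said of these compounds alone.

Of the compounds shown here, three of one spiro-fused family have been tested in a functional assay on MCF7 cells (Homo sapiens) for antiproliferative activity, read by MTT assay, with a stated time of 48 h; on this read-out lower numbers stand for stronger inhibition and higher numbers for weaker inhibition. Compound 1 `N#CC1=C(N)Oc2c(c3nc4ccccc4nc3c3ccccc23)C12C(=O)N(Cc1cnnn1-c1ccccc1Br)c1ccccc12` gives only a limit of > 50000 nM. Compound 2 `N#CC1=C(N)Oc2c(c3nc4ccccc4nc3c3ccccc23)C12C(=O)N(Cc1cnnn1-c1cccc(Br)c1)c1ccccc12` likewise gives only a limit of > 50000 nM. Compound 3 `N#CC1=C(N)Oc2c(N)cc3nc4ccccc4nc3c2C12C(=O)N(Cc1cnnn1-c1cccc(Br)c1)c1ccccc12` also returns only a limit of > 50000 nM. The change 2-bromophenyl in place of 3-bromophenyl on an aromatic nitrogen gives a step that the two limits leave unreadable from compound 2 to compound 1, which cannot be sized because all three values sit at the limit of > 50000 nM in this assay, at which 3 of the 3 values shown sit. How the core of compound 3 differs from that of compound 2 is not broken down here. Compound 4 `N#CC1=C(N)Oc2c(N)cc3nc4ccccc4nc3c2C12C(=O)N(Cc1cnnn1-c1ccccc1Br)c1ccccc12` carries the same kind of change, (2-bromophenyl in place of 3-bromophenyl on an aromatic nitrogen), on the core of compound 3. Its step in this assay is expected to be a step that the limit leaves unreadable from compound 3 to compound 4, resting on the unreadable step that the two limits leave unreadable from compound 2 to compound 1. Compound 4 is therefore estimated at 80000 nM, most likely again reported only as a limit.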

Compound 4, half-maximal inhibitory concentration: 30700 nM
Compound 4: middle estimate off by 2.6-fold (0.42 log units), on the high side; the measured number falls inside the stated range.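

Carried to the second core, 2-bromophenyl in place of 3-bromophenyl gives an at least 1.6-fold lower number from compound 3 to compound 4 (0.21 log units; that floor lies within the scatter) in this assay. That floor does not establish a real gain on this core, though the true step may be larger. It also does not show that the change acts alike on both cores, as neither the step from compound 2 to compound 1 nor any comparison of the two steps can be read: the limit of > 50000 nM in this assay, at which 3 of the 4 values shown sit.

The compounds shown leave open what an unsubstituted phenyl or a chlorophenyl on that aromatic nitrogen would give in this assay. They also leave open whether an amine on the phenyl ring would change the number.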